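Removing One Methoxy Group from Compound 2

The compounds below may be only part of what the source reports. "The series", "measured", "known", "first", "only" and "open" are said of these compounds alone.

Of the compounds shown here, two sharing one core have been measured so far. Compound 1 `COc1ccc(-c2cc(/C=C/C(=O)c3ccc(N)cc3)[nH]n2)cc1` and compound 2 `COc1cc(-c2cc(/C=C/C(=O)c3ccc(N)cc3)[nH]n2)cc(OC)c1OC` differ in how the aromatic ring attached to the core is substituted with methoxy groups. In a functional assay on UO-31 cells (Homo sapiens) for cytotoxicity, read by sulforhodamine B assay, with a stated time of 48 h, tested at 10 uM (a higher number here means a weaker effect of the compound at the concentration tested, a lower number a stronger effect), compound 1 gives -88%, and in this assay compound 2 gives -84%. These two numbers lie within the usual scatter of each other, so no difference between compound 1 and compound 2 can be read from them. Compound 3 `COc1ccc(-c2cc(/C=C/C(=O)c3ccc(N)cc3)[nH]n2)cc1OC` has not yet been measured. It differs from compound 2 by a single change: hydrogen in place of methoxy on an aromatic carbon. Because compound 2 gives -84% and compound 1 gives -88%, both a strong effect, this change is not expected to move the number beyond the scatter. The step is therefore expected to be a number 2 percentage points lower from compound 2 to compound 3 (within the scatter). Compound 3 is estimated to give -86% in this assay, with an expected range from -96% to -70%.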

Compound 3, a percentage reported as activity, at one concentration (the size of the read-out at that concentration, not a potency): 11%
The estimate for compound 3 lay 97 percentage points below the measured number; the whole stated range lies below it.
By their numbers in this assay, from the lowest: compounds 1 and 2 (each within the scatter of the next); then compound 3.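

In this assay, hydrogen in place of the methoxy group that stands ortho to a methoxy group and meta to a large group is far from a silent change: it gives a number 95 percentage points higher from compound 2 to compound 3 (beyond the scatter). The reverse kind of change, methoxy in place of hydrogen on an aromatic carbon, gives a number 99 percentage points higher from compound 1 to compound 3 (beyond the scatter), so among these compounds a methoxy group on this ring has no single direction of effect, and the outcome depends on the substitution of the ring as a whole. Nothing shown here explains this reversal.

On these data alone, it remains open whether the weak effect of compound 3 belongs to this particular arrangement of methoxy groups alone. A hydroxy group, a chlorine atom or an ethoxy group on the same aromatic carbon could show how specific that arrangement is.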